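The compounds below may be only part of what the source reports. "The series", "measured", "known", "first", "only" and "open" are said of these compounds alone.

Working notes on the dithiocarbamate series

The common element is the pyridinylmethyl dithiocarbamate, varied at the sulfur-bound chain. Compound 1 `OCCCSC(=S)NCc1cccnc1` carries a hydroxypropyl chain, and in a functional assay on SK-BR-3 cells (Homo sapiens) for cytotoxicity, read by resazurin assay, with a stated time of 72 h (on this read-out lower numbers stand for stronger inhibition and higher numbers for weaker inhibition), compound 1 gives 1320 nM. Compound 2 `O=C(CCSC(=S)NCc1cccnc1)NCc1ccccc1` carries a benzylamide chain. For compound 2 the result in this assay is a limit of the assay and not a number, > 100000 nM; this is the case described by the limit of > 100000 nM in this assay, at which 1 of the 3 values shown sits. Compound 3 `S=C(NCc1cccnc1)SCCc1nnc(-c2ccc(Cl)cc2)o1` carries the ethyl-linked oxadiazole bearing a 4-chlorophenyl group, and in this assay compound 3 gives 860 nM. Of the two numbers in hand, compound 3 gives the one that sits at the bottom, but its gap to compound 1 lies within the usual scatter, so the two cannot be told apart on these data.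

Compound 4 `Cc1cc(-c2nnc(CCSC(=S)NCc3cccnc3)o2)no1` differs from compound 3 by 5-methyl-1,2-oxazol-3-yl in place of 4-chlorophenyl on an aromatic carbon. Among the compounds with values here, no measured pair shows this change, so the size of the step rests on the neighbouring values alone. In this assay the step from compound 3 to compound 4 is expected to be small, a 1.9-fold higher number from compound 3 to compound 4 (0.27 log units; within the scatter), pointing toward a somewhat higher number, with a real chance that it stays within the scatter. For compound 4 in this assay the estimate is 1600 nM, with a range from 500 nM to 6000 nM.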

Compound 4, half-maximal inhibitory concentration: 1730 nM
Estimate against measurement, compound 4: 1.1-fold (0.03 log units) below; the measured number falls inside the stated range.
By their numbers in this assay, from the lowest: compounds 3, 1 and 4 (each within the scatter of the next). At a limit, above all of these: compound 2.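

Within the data shown here, at the aromatic carbon of the five-membered aromatic ring with 2 nitrogen and 1 oxygen, 5-methyl-1,2-oxazol-3-yl in place of 4-chlorophenyl comes to a 2.0-fold higher number from compound 3 to compound 4 (0.30 log units; within the scatter) in this assay, the first step that can be read at a single place. Among these compounds, the exchange removes a six-membered aromatic ring of carbon only, together with the chlorine, and brings in a five-membered aromatic ring with 2 hetero atoms and 2 hydrogen-bond acceptors, yet compound 3 and compound 4 cannot be told apart on this read-out, so at this position the two groups are interchangeable on the present data, something the earlier compounds, which differ in the whole chain, could not show. No measured property in hand bears on this step or accounts for it.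

This is one exchange at one position, so it does not settle whether the same holds for groups of another kind on this aromatic carbon, such as an amine or a carboxylic acid. Also open, from the compounds shown here alone, is how a longer chain in place of the ethyl link would read in this assay with either of these two groups in place.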